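The compounds below may be only part of what the source reports. "The series", "measured", "known", "first", "only" and "open" are said of these compounds alone.

Measured so far in an assay on cell membranes for binding affinity to Equilibrative nucleoside transporter 1 (Homo sapiens); on this read-out lower numbers stand for stronger inhibition and higher numbers for weaker inhibition:
compound 1, `CNc1nc2c(SCc3ccccc3)ncnc2n1C1O[C@H](CO)[C@@H](O)[C@H]1O`, gives 28 nM
compound 2, `CCCCCCNc1nc2c(SCc3ccccc3)ncnc2n1C1O[C@H](CO)[C@@H](O)[C@H]1O`, gives 3.7 nM

Compound 2 stands with the lower of the two numbers, and the gap to compound 1 is beyond the scatter, as the step of a 7.6-fold lower number from compound 1 to compound 2 (0.88 log units; beyond the scatter) shows. Compound 3, `OC[C@H]1OC(n2c(NC3CCCC3)nc3c(SCc4ccccc4)ncnc32)[C@H](O)[C@@H]1O`, differs from compound 2 by cyclopentyl in place of hexyl on a nitrogen on an aromatic ring. Going by the values given here, only one measured step bears on this change: a 7.6-fold lower number from compound 1 to compound 2 (0.88 log units; beyond the scatter), which concerns the same nitrogen on the shared core and shows a modest gain when a carbon chain replaces hydrogen there. Among the compounds with values here, compound 3 keeps a carbon group on that nitrogen, so a number nearer to compound 2 than to compound 1 is expected; no measured pair compares a chain with a ring, so the range is wide. For compound 3 a change of a 1.6-fold higher number from compound 2 to compound 3 (0.21 log units; within the scatter) is expected, likely within the scatter. The estimate for compound 3 is 6 nM, ranging from 1.5 nM to 25 nM.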

Compound 3, inhibition constant: 0.64 nM
The estimate for compound 3 lay 9.4-fold (0.97 log units) above the measured number, and the stated range ends above it.
By their numbers in this assay, from the lowest: compound 3; then compound 2; then compound 1.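

In this assay, the group on this nitrogen does not act through carbon count alone: cyclopentyl, with 5 carbon atoms against 6 in hexyl, gives a 5.8-fold lower number from compound 2 to compound 3 (0.76 log units; beyond the scatter). The earlier gain from the hexyl chain therefore does not mark the best group here, and the ring goes well beyond the methyl starting point, with a 44-fold lower number from compound 1 to compound 3 (1.64 log units; beyond the scatter). Nothing available here explains why the ring outdoes the chain.

The three compounds leave open whether the gain depends on having a ring at all or on this particular ring size, a question that cyclobutyl, cyclohexyl or a branched chain such as isopropyl could help settle. They also leave open how a ring carrying a hydroxyl group or an amine would compare with plain cyclopentyl on this nitrogen.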